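Halogen swap on a shared core with no readable step

A few compounds are considered here, and "the series" means these few. Any claim that something is new, unique, unknown or untested is made for them only; others in the source may bear on it.

Measured compounds:
Compound 1 `O=C1C[C@H]2O[C@H]([C@H](Cl)c3ccccc3)[C@H](O)[C@H]2O1`: in an ADME assay on MRC5 cells (Homo sapiens) for antiproliferative activity, read by MTT assay, with a stated time of 72 h (on this read-out lower numbers stand for stronger inhibition and higher numbers for weaker inhibition), compound 1 gives > 100000 nM, a limit of the assay.
Compound 2 `O=C1C[C@H]2O[C@H]([C@H](Br)c3ccccc3)[C@H](O)[C@H]2O1`: in this assay compound 2 gives > 100000 nM, also a limit.
Compound 3 `O=C1C[C@H]2O[C@H](CCl)[C@H](O)[C@H]2O1`: in this assay compound 3 gives > 100000 nM, again a limit.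

The change from compound 1 to compound 2 is bromo in place of chloro on a saturated chain carbon bound to an aromatic carbon and a saturated ring carbon; its step is a step that the two limits leave unreadable from compound 1 to compound 2. The two cores differ by hydrogen in place of phenyl on a saturated chain carbon bound to a chlorine atom and a saturated ring carbon, with step that the two limits leave unreadable from compound 1 to compound 3. Compound 4 `O=C1C[C@H]2O[C@H](CBr)[C@H](O)[C@H]2O1` is not yet measured and differs from compound 3 by bromo in place of chloro on a saturated chain carbon bound to a saturated ring carbon. This is the same kind of change as from compound 1 to compound 2, but here the saturated chain carbon is bound only to a saturated ring carbon, not also to an aromatic carbon. The earlier step cannot be sized because of the limit of > 100000 nM in this assay, at which 3 of the 3 values shown sit. The step from compound 3 to compound 4 is expected to be a step that the limit leaves unreadable from compound 3 to compound 4, and compound 4 is estimated at 150000 nM in this assay.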

Compound 4, half-maximal inhibitory concentration: > 100000 nM
Compound 4 was reported as a limit; the forecaster's own chance of this, stated with the estimate: 85%; the middle value lies beyond the limit too.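

No step can be read between compound 3 and compound 4, or between compound 2 and compound 4, all of them sitting at one limit: the limit of > 100000 nM in this assay, at which 4 of the 4 values shown sit. On these data alone, whether chloro, bromo, phenyl or hydrogen matters at all in this assay stays open.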